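The compounds below may be only part of what the source reports. "The series", "measured", "known", "first", "only" and "open" are said of these compounds alone.

Compound 1, with the structure `O=c1ncn(Cc2c(F)cc(F)cc2F)c2ccc(Oc3ccccc3C(F)(F)F)cc12`, is the highest of the three compounds measured here. In an ADME assay on Caco-2 cells (Homo sapiens) for permeability, in the apical to basolateral direction (on this read-out higher numbers stand for higher permeability and lower numbers for lower permeability), compound 1 gives 9.2 10^-6 cm/s. Compound 2, with the structure `NC(=O)c1cccc(Oc2ccc3c(c2)c(=O)ncn3Cc2c(F)cc(F)cc2F)c1C(F)(F)F`, gives 1.9 10^-6 cm/s, and compound 3, with the structure `O=C(Nc1cccnc1)c1cccc(Oc2ccc3c(c2)c(=O)ncn3Cc2c(F)cc(F)cc2F)c1C(F)(F)F`, gives 0.26 10^-6 cm/s. Both lie below compound 1: the step of a 4.8-fold lower number from compound 1 to compound 2 (0.69 log units; beyond the scatter) is modest, and the step of a 35-fold lower number from compound 1 to compound 3 (1.55 log units; beyond the scatter) is large. Between the two substituted compounds, the step of a 7.3-fold lower number from compound 2 to compound 3 (0.86 log units; beyond the scatter) is again modest.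

Compound 4, with the structure `O=c1ncn(Cc2c(F)cc(F)cc2F)c2ccc(Oc3cccc(-c4nc5ncccc5o4)c3C(F)(F)F)cc12`, differs from compound 1 by a group of 9 heavy atoms (6 carbon, 2 nitrogen, 1 oxygen; one five-membered aromatic ring with 2 hetero atoms, one six-membered aromatic ring with 1 hetero atom) in place of a hydrogen atom, on an aromatic carbon. The two measured steps from compound 1 bear on this change, since each of them also puts a group in place of a hydrogen on an aromatic carbon of the shared core, and each lowered the number. The entering group of compound 4 has no hydrogen-bond donors, unlike the groups entering in compound 2 and compound 3, so a drop is expected, but one closer in size to the step to compound 2 than to compound 3. The step expected for compound 4 is a 2.3-fold lower number from compound 1 to compound 4 (0.36 log units; beyond the scatter). Compound 4 is therefore estimated at 4 10^-6 cm/s, with a range from 1.5 10^-6 cm/s to 10 10^-6 cm/s.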

Compound 4, apparent permeability: 3 10^-6 cm/s
Beside the measured number, compound 4's estimate is 1.3-fold (0.12 log units) above it, and the stated range covers the measured number.
By their numbers in this assay, from the lowest: compound 3; then compounds 2 and 4 (each within the scatter of the next); then compound 1.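

On this aromatic carbon, ortho to a trifluoromethyl group, an entering group with no hydrogen-bond donors also lowers the number in this assay, with a 3.1-fold lower number from compound 1 to compound 4 (0.49 log units; beyond the scatter), so among the compounds shown a drop does not require a group that carries donors. The groups in compound 3 and compound 4 both hold 9 heavy atoms of the same elements, yet they stand far apart, with a 12-fold higher number from compound 3 to compound 4 (1.06 log units; beyond the scatter), so the atom count and element make-up of the entering group do not settle the number here, while the much smaller carbamoyl of compound 2 and the group of compound 4 are not told apart, with a 1.6-fold higher number from compound 2 to compound 4 (0.20 log units; within the scatter) lying within the usual scatter. Nothing measured alongside these permeability numbers accounts for any of these differences.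

The compounds shown leave open whether a single ring, such as a phenyl or a pyridin-3-yl attached directly to this carbon, or a small group such as a methyl, an amine or a carboxylic acid, would give a step of similar size. On these data alone, every change shown sits on this one carbon, and whether the same groups would give similar steps elsewhere on the ring also remains open.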